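Acetyl pyrazoline pair: methoxy addition on the aryl ring

The source may report more compounds than this note shows. Statements on the series, on what has been measured and on what is new or still open speak of the compounds shown alone.

Measured compounds:
compound 1, `CC(=O)N1N=C(c2ccccc2)CC1c1cccc(Cl)c1Cl`: 31600 nM
compound 2, `CC(=O)N1N=C(c2cccc([N+](=O)[O-])c2)CC1c1ccccc1`: 8710 nM

Both were run in a functional assay on PC-3 cells (Homo sapiens) for cytotoxicity, read by sulforhodamine B assay, with a stated time of 48 h; a higher number here means a weaker inhibitor, a lower number a stronger inhibitor. Compound 1 gives 31600 nM, compound 2 gives 8710 nM. Of the two numbers, compound 2 has the lower one, and the gap to compound 1 lies beyond the usual scatter; the two differ at more than one place, so that gap is not a single step and is not read further here.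

The next compound, compound 3, `COc1ccc(C2CC(c3cccc([N+](=O)[O-])c3)=NN2C(C)=O)cc1`, keeps the nitrophenyl-bearing core of compound 2 and changes only the other aryl ring: methoxy in place of hydrogen on an aromatic carbon. Among the compounds with values here, no pair of measured compounds shows this change, so its effect in this assay is not known from the present data.

With nothing measured for the change, the step is expected to stay small, most likely within the scatter, with no clear direction; compound 3 is expected to come in at 7000 nM, in the range 2500 nM to 25000 nM. The expected step is a 1.2-fold lower number from compound 2 to compound 3 (0.09 log units; within the scatter).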

Compound 3, half-maximal inhibitory concentration: 7830 nM
Estimate against measurement, compound 3: 1.1-fold (0.05 log units) below; the range from low to high includes it.
By their numbers in this assay, from the lowest: compounds 3 and 2 (each within the scatter of the next); then compound 1.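

In this assay, within the data shown here, the change from phenyl to 4-methoxyphenyl gives the first single-place step: a 1.1-fold lower number from compound 2 to compound 3 (0.05 log units; within the scatter). This place, on a six-membered aromatic ring of carbon only and para to a large group, therefore takes methoxy, with its 2 heavy atoms, with no reading separable from that of the hydrogen compound, at least with the nitrophenyl-bearing core held fixed. This single step gives no trend at the position, and no measurement available here accounts for the outcome.

On these data alone, whether the position stays this flat with an amine, a carboxylic acid or a longer chain such as butoxy in place of methoxy remains open, as does whether a group of any of these kinds would move the number beyond the scatter. Also open, as far as these compounds go, is whether methoxy gives the same outcome on the core of compound 1, whose gaps to compound 2 and compound 3 span more than one place and cannot be read as steps.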